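Hydrazone aryl swaps on the shared core: compound 4 outlook

A few compounds are considered here, and "the series" means these few. Any claim that something is new, unique, unknown or untested is made for them only; others in the source may bear on it.

For the measured compounds named here, compound 3 `Cn1c(=O)c(=O)n(C2CCCC2)c2nc(N/N=C/c3ccc(O)c(Br)c3)ncc21` gives 11600 nM in a functional assay on PC-3 cells (Homo sapiens) for antiproliferative activity, read by MTT assay (on this read-out lower numbers stand for stronger inhibition and higher numbers for weaker inhibition), the lowest of the three numbers so far; compound 1 `Cn1c(=O)c(=O)n(C2CCCC2)c2nc(N/N=C/c3cccc(Cl)c3Cl)ncc21` gives 17200 nM and compound 2 `Cn1c(=O)c(=O)n(C2CCCC2)c2nc(N/N=C/c3ccco3)ncc21` gives 72200 nM. The step of a 1.5-fold lower number from compound 1 to compound 3 (0.17 log units; within the scatter) shows that exchanging one halogenated phenyl for another on the hydrazone carbon barely moves this assay, whereas a 6.2-fold lower number from compound 2 to compound 3 (0.79 log units; beyond the scatter) and a 4.2-fold higher number from compound 1 to compound 2 (0.62 log units; beyond the scatter) show the furan as the outlier. Compound 4 `Cn1c(=O)c(=O)n(C2CCCC2)c2nc(N/N=C/c3ccccc3Cl)ncc21` carries the change (2-chlorophenyl in place of 3-bromo-4-hydroxyphenyl on a carbon with a double bond to nitrogen). Going by the values given here, the closest precedent is the within-scatter step a 1.5-fold lower number from compound 1 to compound 3 (0.17 log units; within the scatter), run in reverse toward a chlorophenyl; the furan steps do not bear on it. The expected step of a 1.3-fold higher number from compound 3 to compound 4 (0.11 log units; within the scatter) therefore stays within the scatter. Compound 4 is estimated at 15000 nM, with a range from 7000 nM to 35000 nM.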

Compound 4, half-maximal inhibitory concentration: 16300 nM
Compound 4: the middle estimate sits 1.1-fold (0.04 log units) below what was measured; low and high end bracket the measured number.
By their numbers in this assay, from the lowest: compounds 3, 4 and 1 (each within the scatter of the next); then compound 2.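

Working from a 1.4-fold higher number from compound 3 to compound 4 (0.15 log units; within the scatter), the step stays within the scatter in this assay, so the hydrogen-bond donor and acceptor of 3-bromo-4-hydroxyphenyl are not needed to hold the number among these compounds. The step of a 1.1-fold lower number from compound 1 to compound 4 (0.02 log units; within the scatter) also lies within the scatter, so hydrogen in place of chloro on an aromatic carbon changes nothing measurable here. The step of a 4.4-fold lower number from compound 2 to compound 4 (0.65 log units; beyond the scatter) lies beyond the scatter and confirms that furan-2-yl stands apart from all three phenyl compounds.

From the compounds shown here alone, the effect of a carboxylic acid or a dimethylamino group on the phenyl ring remains open. No measurement at hand bears on the origin of the gap to the furan.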